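Cyclohexyl ester analogue of compound 2: working notes

The source may report more compounds than this note shows. Statements on the series, on what has been measured and on what is new or still open speak of the compounds shown alone.

Measured so far:
- compound 1, `CC1=C(C(=O)OC2CCCCC2)C(c2ccoc2)NC(=O)N1`: 1%
- compound 2, `CC1=C(C(=O)OC2CCC2)C(c2cccs2)NC(=O)N1`: 2%

Both compounds were tested in an assay on membranes from HeLa cells for displacement of a labelled ligand from adenosine receptor A3 (Homo sapiens), read by scintillation counting, with a stated time of 180 min, tested at 1 uM; a lower number here means less inhibition, a higher number more inhibition at the concentration tested (going by the name of the read-out). In this assay compound 1 gives 1%, and compound 2 gives 2%. The two values lie within the usual scatter of each other, so neither compound can be set apart from the other on these numbers; compound 2 stands level with compound 1.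

Compound 3, `CC1=C(C(=O)OC2CCCCC2)C(c2cccs2)NC(=O)N1`, has not been measured. It differs from compound 2 in one place: cyclohexyl in place of cyclobutyl on an oxygen next to a carbonyl group. Among the compounds with values here, no step between measured compounds isolates this change, since compound 1 and compound 2 differ in two places at once. With both measured values near the floor, a step in this assay is expected to be none beyond the scatter.

For compound 3 the estimated inhibition is 3%, with a range from 0% to 12%; the expected step of a number 1 percentage points higher from compound 2 to compound 3 (within the scatter) is within the scatter.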

Compound 3, a percentage reported as inhibition, at one concentration (the size of the read-out at that concentration, not a potency): 1%
For compound 3 the middle estimate is 2 percentage points above the measured one, and the stated range covers the measured number.
By their numbers in this assay, from the lowest: compounds 1, 3 and 2 (each within the scatter of the next).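

In this assay the change of cyclohexyl in place of cyclobutyl on an oxygen next to a carbonyl group now has a step of its own, a number 1 percentage points lower from compound 2 to compound 3 (within the scatter), so the two rings cannot be told apart at this position at the concentration tested. With the cyclohexyl ester held constant, the step of no change at the digits printed from compound 1 to compound 3 (within the scatter) also separates thiophen-2-yl in place of furan-3-yl on a saturated ring carbon, and neither single change can be read as an effect on inhibition. Nothing available bears on why these values sit so close together.

From the compounds shown here alone, whether any group on this oxygen can move the read-out beyond the scatter remains open. A longer chain, or a ring carrying an amine or a carboxylic acid, would test this position more widely than the two carbocycles shown here.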